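A few compounds are considered here, and "the series" means these few. Any claim that something is new, unique, unknown or untested is made for them only; others in the source may bear on it.

Measured in a functional assay on NCI-H322 cells (Homo sapiens) for antiproliferative activity; on this read-out higher numbers stand for weaker inhibition of growth and lower numbers for stronger inhibition of growth:
compound 1 `COCCCCCCCCCCC/C=C1\CC(CO)(COC(=O)C(C)(C)C)OC1=O`: > 10 ug/mL, a limit
compound 2 `CC(=O)OCCCCCCCCCCCCCCC/C=C1\CC(CO)(COC(=O)C(C)(C)C)OC1=O`: > 10 ug/mL, a limit
compound 3 `CC(C)(C)C(=O)OCCCCCCCCCCCCCCC/C=C1\CC(CO)(COC(=O)C(C)(C)C)OC1=O`: > 10 ug/mL, a limit

Compound 3 gives > 10 ug/mL, which is a limit and not a number. The whole series sits at the limit of > 10 ug/mL in this assay, at which 3 of the 3 values shown sit.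

Compound 4 `CC(=O)NCCCCCCCCCCCCCCC/C=C1\CC(CO)(COC(=O)C(C)(C)C)OC1=O` differs from compound 3 in one place: acetamido in place of ((tert-butyl)carbonyl)oxy on a saturated chain carbon, ten or more bonds along the chain from a double-bonded chain carbon.

Among the compounds with values here, two measured steps bear on this chain end: a step that the two limits leave unreadable from compound 1 to compound 3 and a step that the two limits leave unreadable from compound 2 to compound 3. Neither has a readable size, so no step beyond the scatter and no direction can be expected in this assay. The estimated step is a step that the limit leaves unreadable from compound 3 to compound 4. Compound 4 is expected at 14 ug/mL, with an estimated range of 6 ug/mL to 35 ug/mL.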

Compound 4, concentration for 50% growth inhibition: > 10 ug/mL
Compound 4: only a limit was reported; the forecaster's own chance of this, stated with the estimate: 80%; the middle value is on the limit's open side.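

In this assay compound 4 gives > 10 ug/mL, a limit, so no new step can be read against compound 1, compound 2 or compound 3: the limit of > 10 ug/mL in this assay, at which 4 of the 4 values shown sit.

The compounds shown leave open how these four chain ends rank against one another, and whether any of them gives a measurable value.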